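This account rests on a few compounds, and the source may have more. Where it says the series, first, only, none or still open, it means among the compounds named here.

The measured compounds:
compound 1 `Cc1ccc(CS/C(=C/c2c[nH]c3ccc(Br)cc23)C(=O)c2ccc(Cl)cc2)cc1` gives 1000 nM
compound 2 `O=C(/C(=C\c1c[nH]c2ccc(Br)cc12)SCc1ccc(F)cc1)c1ccc(Cl)cc1` gives 50000 nM
compound 3 `CN(C)c1ccc(/C=C(/SCc2ccc(F)cc2)C(=O)c2ccc(Cl)cc2)cc1` gives 50000 nM

All three numbers come from a functional assay on DU-145 cells (Homo sapiens) for inhibition, read by trypan blue exclusion, with a stated time of 96 h; a lower number here means a stronger inhibitor of growth, a higher number a weaker inhibitor of growth. Compound 1 and compound 2 share a core and differ in one place only: methyl in place of fluoro on an aromatic carbon. That single change made a large step, a 50-fold lower number from compound 2 to compound 1 (1.70 log units; beyond the scatter). Compound 3 differs from compound 2 in the core itself, the difference being (4-(dimethylamino)phenyl in place of 5-bromo-1H-indol-3-yl on a double-bonded chain carbon bound to a double-bonded chain carbon), and this gave no change at the digits printed from compound 2 to compound 3 (within the scatter), so compound 2 and compound 3 stand level with each other.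

Compound 4 `Cc1ccc(CS/C(=C/c2ccc(N(C)C)cc2)C(=O)c2ccc(Cl)cc2)cc1` has not yet been measured. It stands to compound 3 as compound 1 stands to compound 2: the difference is methyl in place of fluoro on an aromatic carbon, and the place of the change is the same in its every word, so this is the same change made a second time, only on the core of compound 3 rather than on the core of compound 2. How far that change carries over is not settled by the data, since it has been seen once, and the two cores differ as already told.

For compound 4 the step of a 10-fold lower number from compound 3 to compound 4 (1.00 log units; beyond the scatter) is expected, smaller than the earlier one, because a 50-fold lower number from compound 2 to compound 1 (1.70 log units; beyond the scatter) was measured on another core and compound 3 sits at 50000 nM. Compound 4 is estimated at 5000 nM, with the likely range 1000 nM to 50000 nM.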

Compound 4, concentration for 50% growth inhibition: > 100000 nM
Compound 4: a limit, no number; the forecaster's own chance of this, stated with the estimate: 20%; middle value at least 20-fold (1.30 log units) from the limit.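

In this assay compound 4 gives > 100000 nM, which is a limit of the assay and not a number. Putting methyl in place of fluoro therefore did not bring the lower number seen on the core of compound 1; on the core of compound 3 the same change gave an at least 2.0-fold higher number from compound 3 to compound 4 (0.30 log units; that floor lies within the scatter), and the two results clearly part ways: the same change on two cores in this assay, a 50-fold lower number (1.70 log units; beyond the scatter) from compound 2 to compound 1 and an at least 2.0-fold higher number (0.30 log units; that floor lies within the scatter) from compound 3 to compound 4, at least 100-fold (2.00 log units) apart, beyond the scatter of two such steps This rests on a single pair of cores and does not show why the change behaves differently on them, nor how far the true figure for compound 4 lies past its limit, while the change of core is itself tied to the group on the benzyl, with an at least 100-fold higher number from compound 1 to compound 4 (2.00 log units; beyond the scatter) for the methyl pair and a very different result for the fluoro pair: the same change on two cores in this assay, no change at the digits printed (within the scatter) from compound 2 to compound 3 and an at least 100-fold higher number (2.00 log units; beyond the scatter) from compound 1 to compound 4, at least 100-fold (2.00 log units) apart, beyond the scatter of two such steps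

Still open, going by these compounds, is how a chloro or a methoxy group at this same place on the ring would behave on each of the two cores, and whether either would follow methyl or fluoro. Also open, on these data alone, is whether the lower number of compound 1 belongs to the 5-bromo-1H-indol-3-yl group specifically, or would survive on a core carrying an amine or a longer chain in its place.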